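A few compounds are considered here, and "the series" means these few. Any claim that something is new, unique, unknown or untested is made for them only; others in the source may bear on it.

Measured in an ADME assay on liver (Mesocricetus auratus) for metabolic stability, using microsomes; on this read-out lower numbers stand for slow clearance and higher numbers for fast clearance:
Compound 1 `O=C(Nc1[nH]nc(-c2ccccn2)c1C1CC1)c1ccccc1F`: > 100 mL.min-1.g-1, a limit of the assay
Compound 2 `N#Cc1ccc(C2CCN(C(=O)Nc3cc(-c4ccccn4)n[nH]3)CC2)cc1`: 80.8 mL.min-1.g-1
Compound 3 `N#Cc1ccc(OC2CCN(C(=O)Nc3cc(-c4ccccn4)n[nH]3)CC2)cc1`: 30.8 mL.min-1.g-1

Among the actual numbers in this assay, compound 3 stands lowest at 30.8 mL.min-1.g-1. The move to it was a 2.6-fold lower number from compound 2 to compound 3 (0.42 log units; beyond the scatter). Compound 4 `O=C(Nc1cc(-c2ccccn2)n[nH]1)N1CCC(Oc2ccccc2)CC1` carries hydrogen in place of cyano on an aromatic carbon, para to a large group (hydrogen in place of cyano on an aromatic carbon). Among the compounds with values here, no measured step makes this change, so a 2.6-fold lower number from compound 2 to compound 3 (0.42 log units; beyond the scatter), made elsewhere in the molecule, offers only a rough guide to size. A modest step toward a higher number is expected, possibly no larger than the scatter. The expected change is a 1.6-fold higher number from compound 3 to compound 4 (0.21 log units; within the scatter). For compound 4 the estimate is 50 mL.min-1.g-1, with an expected range from 20 mL.min-1.g-1 to 100 mL.min-1.g-1.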

Compound 4, intrinsic clearance in microsomes: 98.5 mL.min-1.g-1
Beside the measured number, compound 4's estimate is 2.0-fold (0.29 log units) below it; the range from low to high includes it.
By their numbers in this assay, from the lowest: compound 3; then compounds 2 and 4 (each within the scatter of the next). At a limit, above all of these: compound 1.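

In this assay the 4-cyanophenoxy group gives way to phenoxy with a clear rise (a 3.2-fold higher number from compound 3 to compound 4 (0.50 log units; beyond the scatter)), the first read of cyano at this place. Compound 4 cannot be told apart from compound 2 (a 1.2-fold higher number from compound 2 to compound 4 (0.09 log units; within the scatter)), so among these compounds the low number appears only with the ether oxygen and the cyano together. Compound 1 alone is held at a limit, which leaves little readable room above compound 4: the limit of > 100 mL.min-1.g-1 in this assay, at which 1 of the 4 values shown sits.

Going by these compounds, whether another group at this place, such as a methoxy, an amine or a carboxylic acid, would hold the number down as cyano does stays open.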